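This account rests on a few compounds, and the source may have more. Where it says the series, first, only, none or still open, it means among the compounds named here.

Values in a functional assay on A-431 cells (Homo sapiens) for inhibition, read by MTT assay, with a stated time of 72 h; a lower number here means a stronger inhibitor, a higher number a weaker inhibitor:
compound 1 `Brc1ccc(-c2nnc(SCCCN3CCN(c4nc5ccccc5o4)CC3)o2)cc1`: 57800 nM
compound 2 `Fc1ccc(-c2nnc(SCCCN3CCN(c4nc5ccccc5s4)CC3)o2)cc1`: 67000 nM

In this assay compound 2 gives 67000 nM and compound 1 gives 57800 nM, values within the scatter of each other.

Compound 3 `Brc1ccc(-c2nnc(SCCCN3CCN(c4nc5ccccc5s4)CC3)o2)cc1` follows from compound 2 by bromo in place of fluoro on an aromatic carbon. Among the measured compounds shown here, no step between measured compounds covers this change. Compound 1 also carries the 4-bromophenyl and gives 57800 nM, so no step beyond the scatter is expected in this assay and no direction is favoured. The expected change is a 1.2-fold lower number from compound 2 to compound 3 (0.06 log units; within the scatter) in this estimate. For compound 3 the estimated value is 58000 nM with an expected range from 27000 nM to 120000 nM in this assay.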

Compound 3, half-maximal inhibitory concentration: 51600 nM
Compound 3: middle estimate off by 1.1-fold (0.05 log units), on the high side; measured number inside the range.
By their numbers in this assay, from the lowest: compounds 3, 1 and 2 (each within the scatter of the next).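

In this assay, 4-fluorophenyl to 4-bromophenyl reads as a 1.3-fold lower number from compound 2 to compound 3 (0.11 log units; within the scatter), and 1,3-benzothiazol-2-yl in place of 1,3-benzoxazol-2-yl on the amine nitrogen in a ring reads as a 1.1-fold lower number from compound 1 to compound 3 (0.05 log units; within the scatter). Each place can now be read singly, and both steps lie within the scatter, so neither halogen nor ring exchange separates these compounds. No measurement on hand offers an explanation for these steps. Open, from the compounds shown here alone, is whether a methoxy or an amine on the phenyl ring would give a step beyond the scatter. Going by these compounds, a longer chain to the piperazine nitrogen also remains open.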